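Moving the sulfur within the thiophene ring on compound 1

A few compounds are considered here, and "the series" means these few. Any claim that something is new, unique, unknown or untested is made for them only; others in the source may bear on it.

Measured compounds:
- compound 1, `c1cn2cc(-c3ccsc3)nc(-c3ccc4ncn(C5CCCCC5)c4c3)c2n1`: 21.8%
- compound 2, `CC(=O)c1ccc(-c2cn3ccnc3c(-c3ccc4ncn(C5CCCCC5)c4c3)n2)cc1`: 0.73%
- compound 3, `COc1ccccc1-c1cn2ccnc2c(-c2ccc3ncn(C4CCCCC4)c3c2)n1`: 14.6%

All three share one core and differ only in the aromatic group attached to it. In a functional assay on MDA-MB-468 cells (Homo sapiens) for inhibition, read by sulforhodamine B assay, with a stated time of 48 h, tested at 10 uM (a lower number here means less inhibition, a higher number more inhibition at the concentration tested (going by the name of the read-out)), compound 1 gives the highest number of the three. Compound 3 sits nearest to it, and the gap a number 7.2 percentage points lower from compound 1 to compound 3 (within the scatter) stays within the scatter, so the two cannot be ranked against each other. Compound 2 sits furthest away, with the step of a number 21.1 percentage points lower from compound 1 to compound 2 (beyond the scatter) lying beyond the scatter, and the step of a number 13.9 percentage points higher from compound 2 to compound 3 (beyond the scatter) is also beyond it.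

The unmeasured compound 4, `c1csc(-c2cn3ccnc3c(-c3ccc4ncn(C5CCCCC5)c4c3)n2)c1`, differs from compound 1 only in this way: thiophen-2-yl in place of thiophen-3-yl on an aromatic carbon. Within the data shown here, no measured step swaps one thiophenyl for another; the two known steps from compound 1 each replace thiophen-3-yl by a substituted phenyl, and both lower the number, one modestly and one within the scatter. Since compound 4 keeps the same atoms in a ring of the same kind, a step beyond the scatter is not expected in this assay.

Compound 4 is therefore estimated at 18%, in a range from 4% to 32%, which is expected to mean a step of a number 3.8 percentage points lower from compound 1 to compound 4 (within the scatter).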

Compound 4, a percentage reported as inhibition, at one concentration (the size of the read-out at that concentration, not a potency): 15.1%
Compound 4: the middle estimate sits 2.9 percentage points above what was measured; the measured number falls inside the stated range.
By their numbers in this assay, from the lowest: compound 2; then compounds 3, 4 and 1 (each within the scatter of the next).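

In this assay, among these compounds, the swap of thiophen-3-yl for thiophen-2-yl is the first direct test of where the thiophene is joined to the core, and it gives a number 6.7 percentage points lower from compound 1 to compound 4 (within the scatter) with the same atoms and the same counts of donors and acceptors. At this position, then, the two attachments of the thiophene cannot be told apart, and the thiophen-2-yl group also cannot be separated from 2-methoxyphenyl, with a number 0.5 percentage points higher from compound 3 to compound 4 (within the scatter), while a number 14.4 percentage points higher from compound 2 to compound 4 (beyond the scatter) confirms that the 4-acetylphenyl compound alone stands apart from the other three. Nothing measured here explains why these groups compare as they do.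

The compounds shown leave open how a plain phenyl ring would read at this position, which would help to show whether the acetyl group on compound 2 matters or the phenyl ring itself does. They also leave open whether a furan-2-yl ring, a pyridin-3-yl ring, or a phenyl ring carrying an amine or a carboxylic acid would move the number beyond the scatter in either direction.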